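The compounds below may be only part of what the source reports. "The series", "measured", "known", "first", "only" and "open" are said of these compounds alone.

Within the data shown here, compound 1 `COc1cc(C(=O)c2sc(-c3cccc([N+](=O)[O-])c3)cc2N)cc(OC)c1OC` shows the lower of the two numbers so far: in a functional assay on FM3A cells (Mus musculus) for antiproliferative activity (on this read-out higher numbers stand for weaker inhibition and lower numbers for stronger inhibition), compound 1 gives 17 nM, while compound 2 `COc1cc(C(=O)c2sc(-c3cc(OC)c(OC)c(OC)c3)cc2N)cc(OC)c1OC` gives 3500 nM in this assay, a gap well beyond the scatter. Compound 3 `COc1ccc(-c2cc(N)c(C(=O)c3cc(OC)c(OC)c(OC)c3)s2)cc1` is still unmeasured and differs from compound 1 in one place (4-methoxyphenyl in place of 3-nitrophenyl on an aromatic carbon). With no comparable change among the measured pair, a moderate loss in this assay is expected, and the step of a 3.5-fold higher number from compound 1 to compound 3 (0.55 log units; beyond the scatter) is the estimated size. Compound 3 is therefore expected to give about 60 nM, within a range from 15 nM to 400 nM.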

Compound 3, half-maximal inhibitory concentration: 31 nM
For compound 3 the middle estimate is 1.9-fold (0.29 log units) above the measured one; the measured number falls inside the stated range.
By their numbers in this assay, from the lowest: compounds 1 and 3 (each within the scatter of the next); then compound 2.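

Putting 4-methoxyphenyl in place of 3-nitrophenyl on the aromatic carbon next to the ring sulfur gives a 1.8-fold higher number from compound 1 to compound 3 (0.26 log units; within the scatter) in this assay on the shared core. The 3-nitrophenyl group of compound 1 can therefore be exchanged at this position for another single-ring aryl group without a change beyond the scatter. Nothing measured explains why these two groups read alike. From the compounds shown here alone, how a plain phenyl, a carboxylic acid or an aliphatic amine would read at this carbon remains open.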